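The source may report more compounds than this note shows. Statements on the series, on what has been measured and on what is new or still open speak of the compounds shown alone.

Of the compounds shown here, three built on a shared core have been tested in a functional assay on the whole organism (strain albino) for inhibition, with Rattus norvegicus as the target, read by paw edema, with stated times of 30 min and 1 h, at a dose of 100 mg/kg by the oral route; on this read-out higher numbers stand for more inhibition at the one dose given (going by the name of the read-out) and lower numbers for less inhibition. Compound 1 `COc1ccc(C2CC(c3ccc(OC)c(OC)c3)=NN2)c(OC)c1` gives 38% in this assay. Compound 2 `COc1ccc(C2=NNC(c3c(Cl)cccc3Cl)C2)cc1OC` gives 26%. Compound 3 `COc1ccc(C2=NNC(c3c(Cl)cccc3Cl)C2)cc1` gives 54%. On these numbers compound 2 stands lowest of the three: compound 1 is nearest to it and compound 3 furthest, and both gaps are beyond the usual scatter of repeated measurements.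

Compound 3 differs from compound 2 in one place, hydrogen in place of methoxy on an aromatic carbon, and that change gave a number 28 percentage points higher from compound 2 to compound 3 (beyond the scatter), a modest step.

Compound 4 `COc1ccc(C2=NN(C(=O)CBr)C(c3c(Cl)cccc3Cl)C2)cc1OC` has not yet been measured. It differs from compound 2 in a different place: (bromomethyl)carbonyl in place of hydrogen on an amine nitrogen in a ring. Going by the values given here, none of the measured pairs alters that ring nitrogen, so the one measured step, which concerns an aromatic carbon, does not bear on this change. With no guidance from the data, a step no larger than the scatter is expected in this assay, in either direction, and the uncertainty is wide. For compound 4 the expected value is 30%, with a likely range from 12% to 55%, which would mean an estimated step of a number 4 percentage points higher from compound 2 to compound 4 (within the scatter).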

Compound 4, a percentage reported as inhibition, in the whole organism at one dose (the size of the read-out at that dose, not a potency): 48%
Beside the measured number, compound 4's estimate is 18 percentage points below it; the measured number falls inside the stated range.
By their numbers in this assay, from the lowest: compound 2; then compounds 1, 4 and 3 (each within the scatter of the next, the first and the last beyond it).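

In this assay, the ring nitrogen that carries only a hydrogen in compound 2 turns out to be a place where the read-out can move: putting (bromomethyl)carbonyl on it gave a number 22 percentage points higher from compound 2 to compound 4 (beyond the scatter). Going by these compounds alone, until now the only change seen to matter was on an aromatic carbon, a number 28 percentage points higher from compound 2 to compound 3 (beyond the scatter), so this result adds a second place on the shared core where a single change takes the number beyond the scatter, and both steps are printed as modest. Nothing measured here explains why the number goes up when this group is placed on the nitrogen.

With only this one group on the nitrogen, the compounds shown cannot separate the part played by the bromine from that of the carbonyl, so a plain acetyl group, a longer chain on the carbonyl, or an amine in place of the bromine would each be informative. Within the data shown here, it also remains open whether (bromomethyl)carbonyl on this nitrogen gives a similar step on a compound with a single methoxy on the aromatic ring, such as compound 3, since no pair shows the two changes together.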